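The source may hold more compounds than are shown below. What is called first, only, known or untested is meant among the compounds shown, and "the series" means these compounds.

Measured compounds in an assay on HEK293 cells for displacement of a labelled ligand from Melanocortin receptor 4 (Homo sapiens); a higher number here means a weaker inhibitor, a lower number a stronger inhibitor:
- compound 1, `COc1ccc(CC(C)C(=O)N2CCN(c3ccc(C(F)(F)F)cc3[C@@H](N)CC(C)C)CC2)cc1`, gives 120 nM
- compound 2, `Cc1cc(CC(C)C(=O)N2CCN(c3ccc(C(F)(F)F)cc3[C@@H](N)CC(C)C)CC2)ccc1Cl`, gives 71 nM
- compound 3, `CC(C)C[C@H](N)c1cc(C(F)(F)F)ccc1N1CCN(C(=O)COc2ccc3ccccc3c2)CC1`, gives 2000 nM

Compound 3 has the highest number of the three in this assay: against compound 1 the step is a 17-fold higher number from compound 1 to compound 3 (1.22 log units; beyond the scatter), against compound 2 it is a 28-fold higher number from compound 2 to compound 3 (1.45 log units; beyond the scatter). Compound 4, `CC(C)C[C@H](N)c1cc(C(F)(F)F)ccc1N1CCN(C(=O)COc2cccc(Cl)c2)CC1`, differs from compound 3 in one place: 3-chlorophenyl in place of naphthalen-2-yl on an oxygen on a saturated carbon. Among the compounds with values here, no measured step changes the group on this oxygen, so none bears directly on it. Within the data shown here, the one aryl-for-aryl exchange measured, a 1.7-fold lower number from compound 1 to compound 2 (0.23 log units; within the scatter), lay within the scatter. On that slim basis, compound 4 is expected to stay near compound 3, with a 1.3-fold lower number from compound 3 to compound 4 (0.12 log units; within the scatter) as the estimated step. Compound 4 is therefore estimated at 1500 nM, within 400 nM to 6000 nM.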

Compound 4, inhibition constant: 2600 nM
Estimate against measurement, compound 4: 1.7-fold (0.24 log units) below; low and high end bracket the measured number.
By their numbers in this assay, from the lowest: compounds 2 and 1 (each within the scatter of the next); then compounds 3 and 4 (each within the scatter of the next).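

In this assay, 3-chlorophenyl in place of naphthalen-2-yl on the oxygen gives (a 1.3-fold higher number from compound 3 to compound 4 (0.11 log units; within the scatter)), so one aromatic ring serves here as well as two. The (3-chlorophenoxy)methyl group on the carbonyl carbon also gives large steps from both branched groups (a 22-fold higher number from compound 1 to compound 4 (1.34 log units; beyond the scatter); a 37-fold higher number from compound 2 to compound 4 (1.56 log units; beyond the scatter)), matching those seen with ((naphthalen-2-yl)oxy)methyl. Nothing available explains these steps.

Open, as far as these compounds go, is whether the ether oxygen or the lost methyl branch accounts for them. Also open, from the compounds shown here alone, is how an amine or carboxylic acid on this ring would read.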